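The source may report more compounds than this note shows. Statements on the series, on what has been measured and on what is new or still open speak of the compounds shown alone.

The series shares one core and varies only the group on an amide-type nitrogen. Compound 1 `CCn1c(C(=O)N[C@H](C)C(=O)OC)ccc1C(CC)(CC)c1ccc(OCS(=O)(=O)c2ccccc2)c(C)c1` carries 1-(methoxycarbonyl)ethyl there; in a functional assay on MCF7 cells (Homo sapiens) for antiproliferative activity, read by MTT assay, with a stated time of 24 h (on this read-out higher numbers stand for weaker inhibition and lower numbers for stronger inhibition), compound 1 gives > 50000 nM, which is a limit of the assay and not a number (the limit of > 50000 nM in this assay, at which 1 of the 3 values shown sits). Compound 2 `CCn1c(C(=O)NCCN)ccc1C(CC)(CC)c1ccc(OCS(=O)(=O)c2ccccc2)c(C)c1` carries 2-aminoethyl and gives 6470 nM in this assay. Compound 3 `CCn1c(C(=O)N[C@@H](CO)CCO)ccc1C(CC)(CC)c1ccc(OCS(=O)(=O)c2ccccc2)c(C)c1` carries 3-hydroxy-1-(hydroxymethyl)propyl and gives 27400 nM in this assay, the highest of the two numbers; the step of a 4.2-fold higher number from compound 2 to compound 3 (0.63 log units; beyond the scatter) separates it from compound 2, while an at least 1.8-fold lower number from compound 1 to compound 3 (0.26 log units; that floor lies within the scatter) and an at least 7.7-fold lower number from compound 1 to compound 2 (0.88 log units; beyond the scatter) run from the limit of compound 1.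

Compound 4 `CCn1c(C(=O)NCCC(=O)O)ccc1C(CC)(CC)c1ccc(OCS(=O)(=O)c2ccccc2)c(C)c1` differs from compound 3 at the amide-type nitrogen alone: 2-carboxyethyl in place of 3-hydroxy-1-(hydroxymethyl)propyl on an amide-type nitrogen. Going by the values given here, no measured step brings in a carboxylic acid; the nearest comparisons are a 4.2-fold higher number from compound 2 to compound 3 (0.63 log units; beyond the scatter) and an at least 1.8-fold lower number from compound 1 to compound 3 (0.26 log units; that floor lies within the scatter), which place compound 3 between compound 2 and the limit of compound 1. Among the compounds with values here, with no acid precedent, the step of a 1.3-fold higher number from compound 3 to compound 4 (0.11 log units; within the scatter) is expected to stay within the scatter. The estimate for compound 4 in this assay is therefore 35000 nM, between 12000 nM and 100000 nM, with a real chance that only a limit is reported.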

Compound 4, half-maximal inhibitory concentration: > 50000 nM
Compound 4: no number, only a limit (the forecaster's own chance of this, stated with the estimate: 35%); middle value at least 1.4-fold (0.15 log units) from the limit.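

In this assay compound 4 gives > 50000 nM, which is a limit and not a number, and it is the second compound at that limit: the limit of > 50000 nM in this assay, at which 2 of the 4 values shown sit. Carboxy in place of amino on a saturated chain carbon, two bonds along the chain from an amide-type nitrogen, gives an at least 7.7-fold higher number from compound 2 to compound 4 (0.88 log units; beyond the scatter) and is the first change here made at the end of the chain alone, which shows that the chain by itself does not carry the number of compound 2. The step of an at least 1.8-fold higher number from compound 3 to compound 4 (0.26 log units; that floor lies within the scatter) does not separate the two compounds, and the step between compound 1 and compound 4 cannot be read.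

The compounds shown leave open whether a dimethylamino group or a longer aminopropyl chain on the amide-type nitrogen would hold the number of compound 2. They also leave open how the methyl ester of 2-carboxyethyl would read against compound 4.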